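A few compounds are considered here, and "the series" means these few. Any claim that something is new, unique, unknown or untested is made for them only; others in the source may bear on it.

Measured so far:
compound 1, `O=C(/C=C/c1ccccc1)Nc1cc2ncnc(Nc3ccc(F)c(Cl)c3)c2s1`: 200 nM
compound 2, `O=C(/C=C/c1ccc(O)cc1)Nc1cc2c(Nc3ccc(Cl)c(Cl)c3)ncnc2s1`: 300 nM

Both numbers come from a functional assay on PC-3 cells (Homo sapiens) for antiproliferative activity, read by MTT assay, with a stated time of 48 h; a lower number here means a stronger inhibitor, a higher number a weaker inhibitor. Compound 1 gives the lowest of the two numbers, and compound 2 lies within the scatter of it, so no order between the two can be read.

The next compound, compound 3, `O=C(/C=C/c1ccccc1)Nc1cc2ncnc(Nc3ccc(Cl)c(Cl)c3)c2s1`, has not yet been measured. It differs from compound 1 by chloro in place of fluoro on an aromatic carbon. Within the data shown here, compound 2 also carries a (3,4-dichlorophenyl)amino group, but it differs from compound 1 in more than one place, so no single-point step is available and the effect of this exchange cannot be read from the two measured values alone.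

On the numbers shown, the expectation for compound 3 in this assay is a small step from compound 1, with no direction that goes beyond the scatter. The step from compound 1 to compound 3 is estimated as a 1.1-fold higher number from compound 1 to compound 3 (0.04 log units; within the scatter). For compound 3 the estimate is 220 nM, with a range from 100 nM to 500 nM.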

Compound 3, half-maximal inhibitory concentration: 260 nM
Compound 3: the middle estimate sits 1.2-fold (0.07 log units) below what was measured; the measured number falls inside the stated range.
By their numbers in this assay, from the lowest: compounds 1, 3 and 2 (each within the scatter of the next).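

In this assay, chloro in place of fluoro on the aromatic carbon, ortho to a chloro group and para to a large group, gives a 1.3-fold higher number from compound 1 to compound 3 (0.11 log units; within the scatter). Among these compounds, this is the only pair so far that differs in one place, and it turns the open question left by the earlier compounds into a direct reading: on the shared core with the unsubstituted cinnamoyl amide, the 3-chloro-4-fluorophenyl and 3,4-dichlorophenyl groups cannot be told apart in this assay. The finding rests on this single pair and covers these two halogens only, and no measurement bearing on why the two groups read alike is available.

The compounds shown leave open whether this position tolerates anything other than a halogen, such as hydrogen, a methoxy group, a trifluoromethyl group or a bromo group, any of which could give a step beyond the scatter. They also leave open whether the same exchange reads alike when the cinnamoyl phenyl ring carries a substituent such as a hydroxy or an amine.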